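Compound 3 to compound 4: a carbonyl-side aryl swap

A few compounds are considered here, and "the series" means these few. Any claim that something is new, unique, unknown or untested is made for them only; others in the source may bear on it.

In an ADME assay on MT4 cells (Homo sapiens) for cytotoxicity, read by MTT assay (on this read-out higher numbers stand for lower toxicity in this test and lower numbers for higher toxicity in this test), compound 1 `Cc1ccccc1C(=O)N(C(=S)OCCN1C(=O)c2ccccc2C1=O)c1ccc(Cl)cc1` gives 21000 nM, compound 2 `Cc1cccc(C(=O)N(C(=S)OCCN2C(=O)c3ccccc3C2=O)c2ccc(Cl)cc2)c1` gives 58000 nM and compound 3 `O=C1c2ccccc2C(=O)N1CCOC(=S)N(C(=O)c1ccc(Cl)cc1Cl)c1ccc(Cl)cc1` gives 18000 nM. Compound 3 stands at the low end of these numbers, level with compound 1 and under compound 2. The two steps that place it are a 1.2-fold lower number from compound 1 to compound 3 (0.07 log units; within the scatter) and a 3.2-fold lower number from compound 2 to compound 3 (0.51 log units; beyond the scatter).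

Compound 4 `O=C1c2ccccc2C(=O)N1CCOC(=S)N(C(=O)c1ccc(Cl)c([N+](=O)[O-])c1)c1ccc(Cl)cc1` is still unmeasured. It carries 4-chloro-3-nitrophenyl in place of 2,4-dichlorophenyl on a carbonyl carbon, and the change counts as 4-chloro-3-nitrophenyl in place of 2,4-dichlorophenyl on a carbonyl carbon.

All three measured steps are swaps at this same place, and the largest is a 2.8-fold higher number from compound 1 to compound 2 (0.44 log units; beyond the scatter), which is only modest. Among the compounds with values here, no measured compound carries a nitro group, so the direction rests on weak ground. Since compound 3 sits at the low end, a small rise is slightly more likely than a fall. The expected change is a 1.5-fold higher number from compound 3 to compound 4 (0.18 log units; within the scatter), which would not exceed the scatter. For compound 4 the estimated value is 27000 nM, with an expected range of 11000 nM to 65000 nM.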

Compound 4, half-maximal cytotoxic concentration: 48000 nM
Compound 4: middle estimate off by 1.8-fold (0.25 log units), on the low side; measured number inside the range.
By their numbers in this assay, from the lowest: compounds 3 and 1 (each within the scatter of the next); then compounds 4 and 2 (each within the scatter of the next).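

In this assay, this carbonyl-side position now accepts a nitro-bearing aryl group without a move towards the low end: 4-chloro-3-nitrophenyl in place of 2,4-dichlorophenyl gives a 2.7-fold higher number from compound 3 to compound 4 (0.43 log units; beyond the scatter), a modest step. Against the other two aryl groups, the same group gives a 2.3-fold higher number from compound 1 to compound 4 (0.36 log units; beyond the scatter), also beyond the scatter, and a 1.2-fold lower number from compound 2 to compound 4 (0.08 log units; within the scatter), within it, so the four compounds fall into two levels, with compounds 1 and 3 in the lower pair and compounds 2 and 4 in the upper pair. No measurement on these compounds accounts for these steps.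

On these data alone, whether the split tracks 3-methylphenyl and 4-chloro-3-nitrophenyl against 2-methylphenyl and 2,4-dichlorophenyl as a general pattern stays open with only four compounds. As far as these compounds go, how an amine or a carboxylic acid on this aryl ring would read also stays open, as does any change elsewhere on the shared core.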